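The compounds below may be only part of what the source reports. "The series", "measured", "known", "first", "only" and "open" are said of these compounds alone.

Compound 1 `N#Cc1c(Cl)nc(SCc2nc3ccccc3[nH]2)nc1-c1ccccc1` is tested in a functional assay on NCI-H460 cells (Homo sapiens) for cytotoxicity, read by MTT assay, with a stated time of 3 days (a higher number here means a weaker inhibitor, a lower number a stronger inhibitor), where compound 1 gives 3.28 nM, the lowest of the two numbers at hand. Among the measured compounds shown here, its one neighbor is compound 2 `N#Cc1c(NC(N)=O)nc(SCc2nc3ccccc3[nH]2)nc1-c1ccccc1`, which in this assay gives 14.7 nM; the change of a 4.5-fold higher number from compound 1 to compound 2 (0.65 log units; beyond the scatter) shows that replacing the chloro weakened inhibition. Compound 3 `N#Cc1c(-c2ccccc2)nc(SCc2nc3ccccc3[nH]2)nc1N1CCNCC1` differs from compound 1 as follows: piperazin-1-yl in place of chloro on an aromatic carbon. For the measured compounds named here, the only step bearing on it is that from compound 1 to compound 2, a modest weakening, so a weakening of similar order is expected here, giving a 3.0-fold higher number from compound 1 to compound 3 (0.48 log units; beyond the scatter). Compound 3 is therefore estimated at 10 nM, within 3 nM to 40 nM.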

Compound 3, half-maximal inhibitory concentration: 7.35 nM
Compound 3: middle estimate off by 1.4-fold (0.13 log units), on the high side; measured number inside the range.
By their numbers in this assay, from the lowest: compound 1; then compounds 3 and 2 (each within the scatter of the next).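

This position accepts a much bigger group than chloro: piperazin-1-yl brings a six-membered non-aromatic ring and a hydrogen-bond donor, yet in this assay the change is only a 2.2-fold higher number from compound 1 to compound 3 (0.35 log units; beyond the scatter) and the compound stays in the low nanomolar range. Two quite different groups, ureido and piperazin-1-yl, cannot be told apart here, given a 2.0-fold lower number from compound 2 to compound 3 (0.30 log units; within the scatter) and compound 1 stays lowest, with its steps to both beyond the scatter. Going by these compounds, whether a morpholine ring or a simple dimethylamino group would come closer to chloro stays open. No measurement at hand explains these differences.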